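Methoxy for ethyl on a thiosemicarbazone: an unmeasured step

This account rests on a few compounds, and the source may have more. Where it says the series, first, only, none or still open, it means among the compounds named here.

Measured compounds:
- Compound 1 `S=C(N/N=C/c1cccs1)Nc1cccc2ccccc12`: > 100000 nM
- Compound 2 `CCc1ccc(NC(=S)N/N=C/c2cccs2)cc1`: > 100000 nM
- Compound 3 `S=C(N/N=C/c1cccs1)Nc1ccc(Cl)cc1`: > 100000 nM

In a functional assay on NCI-H460 cells (Homo sapiens) for inhibition, read by sulforhodamine B assay, with a stated time of 48 h (a higher number here means a weaker inhibitor of growth, a lower number a stronger inhibitor of growth), compound 1 gives > 100000 nM, which is a limit of the assay and not a number. In this assay compound 2 likewise gives > 100000 nM, again a limit. In this assay compound 3 gives > 100000 nM, also a limit. So compound 2 stands at the limit, as do the other two; none of the three shows a number that could place it above or below the others.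

The change from compound 2 to compound 4 `COc1ccc(NC(=S)N/N=C/c2cccs2)cc1` is this: methoxy in place of ethyl on an aromatic carbon.

Among the measured compounds shown here, only one measured step resembles it, a step that the two limits leave unreadable from compound 2 to compound 3, and its size cannot be read because both ends sit at the limit of > 100000 nM in this assay, at which 3 of the 3 values shown sit. For the measured compounds named here, the evidence gives no step with a measurable size, so no shift in this assay can be predicted beyond the scatter, in either direction. Given that all three measured compounds sit at the limit, compound 4 is expected to sit there too, with a step that the limit leaves unreadable from compound 2 to compound 4. The estimate for compound 4 in this assay is 150000 nM, with a range from 50000 nM to 500000 nM.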

Compound 4, concentration for 50% growth inhibition: > 100000 nM
Compound 4 was reported as a limit (the forecaster's own chance of this, stated with the estimate: 85%); the middle value is on the limit's open side.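

In this assay compound 4 gives > 100000 nM, which is a limit, so neither the step from compound 2 nor the step from compound 3 to compound 4 can be read. The compounds shown leave open how strongly each inhibits growth, and whether ethyl, chloro and methoxy differ at all: the limit of > 100000 nM in this assay, at which 4 of the 4 values shown sit.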